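Swapping the substituted alkyl group on compound 2

A few compounds are considered here, and "the series" means these few. Any claim that something is new, unique, unknown or untested is made for them only; others in the source may bear on it.

- compound 1 `CCCC(C#N)(CC)Nc1nc(NC)nc(-n2cncn2)n1`: 29 mL/min/kg
- compound 2 `CCC(C)(C#N)Nc1nc(NC)nc(-n2cncn2)n1`: 32 mL/min/kg
- compound 3 `CNc1nc(NC2(C#N)CCCCC2)nc(OC)n1`: 196 mL/min/kg

In an ADME assay on microsomes from liver (Rattus norvegicus) for metabolic stability (on this read-out lower numbers stand for slow clearance and higher numbers for fast clearance), compound 2 gives 32 mL/min/kg, within the scatter of compound 1 and well under compound 3 at 196 mL/min/kg. Compound 4 `C#CC(CC)(CC)Nc1nc(NC)nc(-n2cncn2)n1` carries 1,1-diethylprop-2-yn-1-yl in place of 1-cyano-1-methylpropyl on a nitrogen on an aromatic ring. Going by the values given here, the one measured step, a 1.1-fold higher number from compound 1 to compound 2 (0.04 log units; within the scatter), stays within the scatter, but it keeps the nitrile, so it bears only loosely on this change. Among the compounds with values here, no measured step replaces the nitrile. Compound 3 differs in more than one place and shows only how high values in this set can go. A moderate rise in this assay is expected, a 1.9-fold higher number from compound 2 to compound 4 (0.27 log units; within the scatter), with wide uncertainty. For compound 4 the estimated clearance is 60 mL/min/kg, with a range of 25 mL/min/kg to 150 mL/min/kg.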

Compound 4, clearance: 22 mL/min/kg
Compound 4: middle estimate off by 2.7-fold (0.44 log units), on the high side; measured number outside the range, below it.
By their numbers in this assay, from the lowest: compounds 4, 1 and 2 (each within the scatter of the next); then compound 3.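

Unlike the earlier step on this nitrogen, this change removes the nitrile: with 1,1-diethylprop-2-yn-1-yl in place of 1-cyano-1-methylpropyl, this assay gives a 1.5-fold lower number from compound 2 to compound 4 (0.16 log units; within the scatter). At this position, in this one pair, the nitrile can therefore be exchanged without the read-out moving beyond the scatter. Nothing available accounts for this result. Open, on these data alone, is whether a chain carrying an amine or a carboxylic acid on this nitrogen would also stay within the scatter of compound 2. As far as these compounds go, a longer chain in place of the ethyl groups is equally open.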